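Swapping a trifluoromethyl for chloro on the urea aryl

The compounds below may be only part of what the source reports. "The series", "measured", "known", "first", "only" and "open" are said of these compounds alone.

Compound 2, `COc1cc(Cl)cc(-c2nn(-c3cccc(NC(=O)Nc4ccc(Cl)c(C(F)(F)F)c4)c3)cc2-c2ccncc2)c1`, gives -48.3% in a functional assay on COLO 205 cells (Homo sapiens) for inhibition, read by sulforhodamine B assay, with a stated time of 48 h, tested at 10 uM (on this read-out higher numbers stand for a weaker effect at the one concentration tested and lower numbers for a stronger effect), the lower of the two numbers measured. Compound 1, `O=C(Nc1cccc(-n2cc(-c3ccncc3)c(-c3cc(O)cc(Cl)c3)n2)c1)Nc1ccc(Cl)c(Cl)c1`, gives 22.4% in this assay, a gap beyond the usual scatter. Compound 3, `COc1cc(Cl)cc(-c2nn(-c3cccc(NC(=O)Nc4ccc(Cl)c(Cl)c4)c3)cc2-c2ccncc2)c1`, carries chloro in place of trifluoromethyl on an aromatic carbon. Among the compounds with values here, no measured pair shows this exact change, so its effect is unknown; a modest shift toward a weaker effect, or none beyond the scatter, is expected as a number 23.3 percentage points higher from compound 2 to compound 3 (beyond the scatter). Compound 3 is therefore estimated at -25%, within a range from -65% to 20%.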

Compound 3, a percentage reported as activity, at one concentration (the size of the read-out at that concentration, not a potency): -70.3%
Compound 3: the middle estimate sits 45.3 percentage points above what was measured; the whole stated range lies above it.
By their numbers in this assay, from the lowest: compound 3; then compound 2; then compound 1.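

In this assay, chloro in place of trifluoromethyl on this aromatic carbon does not weaken the effect: it gives a number 22 percentage points lower from compound 2 to compound 3 (beyond the scatter), a stronger effect. With the 3,4-dichlorophenyl kept, methyl in place of hydrogen on the oxygen on the aromatic ring gives a number 92.7 percentage points lower from compound 1 to compound 3 (beyond the scatter), a far larger step than the swap of chloro for trifluoromethyl. No evidence at hand explains either step. Open, as far as these compounds go, is how fluoro or a nitrile would read on that aromatic carbon, and how an ethyl group would read on the oxygen.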